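The source may report more compounds than this note shows. Statements on the series, on what has been measured and on what is new or still open speak of the compounds shown alone.

Working notes on the series. In a functional assay on HEK293 cells for agonist activity at G-protein coupled receptor 84 (Homo sapiens), read by calcium flux (on this read-out lower numbers stand for smaller maximal responses and higher numbers for larger maximal responses), compound 3 `CCCCCCCCCc1nc(O)cc(O)n1` gives 84.1%, the lowest of the three measured numbers. Compound 2 `CCc1ccc(CCc2nc(O)cc(O)n2)cc1` gives 97.4% and compound 1 `CCCCCCc1nc(O)cc(O)n1` gives 99.7% in this assay, both beyond the scatter above compound 3. Among the measured compounds shown here, the only measured step that concerns chain length, a number 15.6 percentage points lower from compound 1 to compound 3 (beyond the scatter), is modest. Compound 4 `CCCCCCCCc1nc(O)cc(O)n1` differs from compound 3 by hydrogen in place of methyl on a saturated chain carbon, eight bonds along the chain from an aromatic carbon, which takes the chain back by one carbon toward that of compound 1. On the evidence of the step from compound 1 to compound 3, a smaller change in the same chain is expected to give a small rise: a number 6.9 percentage points higher from compound 3 to compound 4 (within the scatter). Compound 4 is therefore estimated at 91%, with a range of 80% to 101%.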

Compound 4, largest response reached (reported as percent of maximum), in percent of the reference or control that the assay uses: 110%
Estimate against measurement, compound 4: 19 percentage points below; the measured number lies above the stated range.
By their numbers in this assay, from the lowest: compound 3; then compounds 2 and 1 (each within the scatter of the next); then compound 4.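

Hydrogen in place of methyl, eight bonds along the chain from an aromatic carbon, gives a number 25.9 percentage points higher from compound 3 to compound 4 (beyond the scatter) in this assay and is the largest listed change at this chain. Ethyl in place of hydrogen, six bonds along the chain from an aromatic carbon, gives a number 10.3 percentage points higher from compound 1 to compound 4 (beyond the scatter) as well, so the response rises from compound 1 to compound 4, and compound 3 goes against any steady rise with chain length. Nothing available accounts for this turn. As far as these compounds go, whether a longer chain than that of compound 3 lowers the response further remains open, as does whether a carboxylic acid at the chain end keeps it.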